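The compounds below may be only part of what the source reports. "The series", "measured", "known", "first", "only" and "open" are said of these compounds alone.

The three measured compounds and their numbers:

Compound 1, `CC1(C)C=C(n2ccccc2=O)c2cc(C(=O)c3ccco3)ccc2O1`, gives 6.49 in a functional assay (aorta) with Rattus norvegicus as the target; a lower number here means a less potent compound, a higher number a more potent compound, by a factor of ten per unit of this negative logarithm.
Compound 2, `CC1(C)C=C(n2ccccc2=O)c2cc(OCC(=O)c3ccccc3)ccc2O1`, gives 5.05 in this assay.
Compound 3, `CC1(C)C=C(n2ccccc2=O)c2cc(OC(=O)Nc3ccc(F)cc3)ccc2O1`, gives 5.3 in this assay.

Among these three, compound 1 stands highest. Compound 3 is nearest to it, and compound 2 furthest, and both of those gaps are beyond the scatter. The unmeasured compound 4, `CC1(C)C=C(n2ccccc2=O)c2cc(C(F)(F)F)ccc2O1`, differs from compound 1 in one place: trifluoromethyl in place of (furan-2-yl)carbonyl on an aromatic carbon.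

Going by the values given here, only one measured step is available, a number 0.25 log units higher from compound 2 to compound 3 (within the scatter), and it exchanges one oxygen-borne group for another rather than touching the kind of change made here, so it bears on compound 4 only loosely. What the numbers of compounds 2 and 3 do show is that every other group tried at this position of the shared core sits well under compound 1. With nothing that resembles a trifluoromethyl in hand, the expectation is a loss from compound 1, of uncertain size, with a wide range. Compound 4 is therefore estimated at 5.7, between 5 and 6.5, an expected step of a number 0.79 log units lower from compound 1 to compound 4 (beyond the scatter).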

Compound 4, logarithm of the reciprocal of the active concentration, log(1/C): 7.61
For compound 4 the middle estimate is 1.91 log units below the measured one; the whole stated range lies below it.
By their numbers in this assay, from the lowest: compounds 2 and 3 (each within the scatter of the next); then compound 1; then compound 4.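

In this assay the step to trifluoromethyl gives a number 1.12 log units higher from compound 1 to compound 4 (beyond the scatter) and so shows that the (furan-2-yl)carbonyl of compound 1 does not mark the top of what this aromatic carbon of the shared core allows. Compound 4 carries neither the five-membered aromatic ring nor the carbonyl of the group that leaves, and it still gives 7.61, so neither of these features is required at this place for a high number in this assay. The compounds shown hold no measurement that explains the size of this rise.

They leave open whether the high number belongs to trifluoromethyl in particular or extends to other groups without a ring on this carbon, since a methyl, a chlorine atom and a nitrile stand among none of them. They also leave open how much of the step from compound 1 goes with the loss of the furan ring and how much with the loss of the carbonyl, which an acetyl group or a furan-2-yl group attached directly to this carbon could begin to separate.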